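From 3-Hydroxypropyl to Carboxy on the Shared Core

This account rests on a few compounds, and the source may have more. Where it says the series, first, only, none or still open, it means among the compounds named here.

Measured in a functional assay on P388 cells (Mus musculus) for cytotoxicity; a lower number here means a stronger inhibitor, a higher number a weaker inhibitor:
Compound 1 `COC(=O)C[C@@H]1NC(=O)[C@@H](C)NC(=O)[C@@H]2Cc3ccc(OC)c(c3)Oc3ccc(cc3)C[C@@H](C(=O)N2C)N(C)C(=O)[C@H](C)NC(=O)[C@H](Cc2ccc(OC)cc2)N(C)C1=O`: 41.7 nM
Compound 2 `COc1ccc(C[C@H]2C(=O)N[C@@H](C)C(=O)N(C)[C@H]3Cc4ccc(cc4)Oc4cc(ccc4OC)C[C@@H](C(=O)N[C@H](C)C(=O)N[C@@H](CC=O)C(=O)N2C)N(C)C3=O)cc1`: 33.9 nM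
Compound 3 `COc1ccc(C[C@H]2C(=O)N[C@@H](C)C(=O)N(C)[C@H]3Cc4ccc(cc4)Oc4cc(ccc4OC)C[C@@H](C(=O)N[C@H](C)C(=O)N[C@@H](CCCCO)C(=O)N2C)N(C)C3=O)cc1`: 219 nM

Compound 3 holds the highest of the three numbers in this assay, and it is the series' outlier: compounds 1 and 2 lie within the scatter of each other, as a 1.2-fold lower number from compound 1 to compound 2 (0.09 log units; within the scatter) shows. The next structure is compound 4 `COc1ccc(C[C@H]2C(=O)N[C@@H](C)C(=O)N(C)[C@H]3Cc4ccc(cc4)Oc4cc(ccc4OC)C[C@@H](C(=O)N[C@H](C)C(=O)N[C@@H](CC(=O)O)C(=O)N2C)N(C)C3=O)cc1`, and the change is carboxy in place of 3-hydroxypropyl on a saturated chain carbon bound to a saturated ring carbon.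

Among the measured compounds shown here, no measured compound carries carboxy, so the nearest evidence is indirect. It comes from a 5.3-fold higher number from compound 1 to compound 3 (0.72 log units; beyond the scatter) and a 6.5-fold higher number from compound 2 to compound 3 (0.81 log units; beyond the scatter), which introduced 3-hydroxypropyl in place of methoxycarbonyl and formyl. Carboxy, like those two groups, holds a carbonyl, so a move toward a lower number is expected, though a smaller one than those steps, and possibly none beyond the scatter. The expected step is a 1.5-fold lower number from compound 3 to compound 4 (0.16 log units; within the scatter).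

For compound 4 the estimate is 150 nM, with an expected range of 35 nM to 700 nM.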

Compound 4, half-maximal inhibitory concentration: 1200 nM
Compound 4: the middle estimate sits 8.0-fold (0.90 log units) below what was measured; the whole stated range lies below it.
By their numbers in this assay, from the lowest: compounds 2 and 1 (each within the scatter of the next); then compound 3; then compound 4.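

At this position, on a saturated chain carbon bound to a saturated ring carbon, carboxy gives the highest number of the four compounds in this assay, with a 5.5-fold higher number from compound 3 to compound 4 (0.74 log units; beyond the scatter), so a carbonyl alone does not keep the number low. The contrast is sharper against the other two carbonyl-bearing groups, which lie within the scatter of each other: carboxy in place of methoxycarbonyl gives a 29-fold higher number from compound 1 to compound 4 (1.46 log units; beyond the scatter), and hydroxy in place of hydrogen on the carbonyl carbon gives a 35-fold higher number from compound 2 to compound 4 (1.55 log units; beyond the scatter). Nothing shown here explains this rise.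

On these data alone, it remains open whether a primary amide or an amine on this carbon would stay with compounds 1 and 2 or fall in with compound 4. As far as these compounds go, it is equally open whether a longer chain ending in carboxy would recover any of the loss.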